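Fluoro in place of trifluoromethyl: compound 3 to compound 4

The source may hold more compounds than are shown below. What is called first, only, known or untested is meant among the compounds shown, and "the series" means these compounds.

Measured in a functional assay on HepG2 cells (Homo sapiens) for cytotoxicity, read by MTT assay, with a stated time of 24 h; on this read-out higher numbers stand for weaker inhibition and lower numbers for stronger inhibition:
- compound 1 `CN1C/C(=C\c2ccncc2)C(=O)/C(=C/c2ccccc2F)C1`: 4600 nM
- compound 2 `O=C1/C(=C/c2ccncc2)CN(S(=O)(=O)c2ccc([N+](=O)[O-])cc2)C/C1=C\c1ccccc1F`: 11300 nM
- compound 3 `O=C1/C(=C/c2ccncc2)CN(S(=O)(=O)c2ccc(C(F)(F)F)cc2)C/C1=C\c1ccccc1F`: 4030 nM

Compound 3, at 4030 nM, shares the low end of these numbers with compound 1, at 4600 nM, since the two lie within the scatter of each other. Compound 2 stands clearly higher. The next compound, compound 4 `O=C1/C(=C/c2ccncc2)CN(S(=O)(=O)c2ccc(F)cc2)C/C1=C\c1ccccc1F`, differs from compound 3 by fluoro in place of trifluoromethyl on an aromatic carbon, para to a large group. Among the compounds with values here, only one measured step bears on this change: a 2.8-fold lower number from compound 2 to compound 3 (0.45 log units; beyond the scatter). That step was modest and replaced nitro with trifluoromethyl on the same aromatic carbon. Within the data shown here, no measured compound carries fluoro there, so the direction is poorly defined. A step smaller than that modest one is therefore expected, probably within the scatter and leaning slightly towards a higher number. The expected change is a 1.2-fold higher number from compound 3 to compound 4 (0.09 log units; within the scatter). For compound 4 the estimate is 5000 nM, with an expected range of 2500 nM to 10000 nM.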

Compound 4, half-maximal inhibitory concentration: 20300 nM
The estimate for compound 4 lay 4.1-fold (0.61 log units) below the measured number; measured number outside the range, above it.
By their numbers in this assay, from the lowest: compounds 3 and 1 (each within the scatter of the next); then compounds 2 and 4 (each within the scatter of the next).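

In this assay, this place on the aromatic ring proves sensitive to the group it carries, and trifluoromethyl stands apart from fluoro, with a 5.0-fold higher number from compound 3 to compound 4 (0.70 log units; beyond the scatter) as the measured step. Fluoro and nitro do not separate in the same way, since a 1.8-fold higher number from compound 2 to compound 4 (0.25 log units; within the scatter) remains within the scatter, so among these three groups only trifluoromethyl gives the lower number. The step at the ring nitrogen, a 4.4-fold higher number from compound 1 to compound 4 (0.64 log units; beyond the scatter) on going from methyl to (4-fluorophenyl)sulfonyl, shows that this sulfonyl group does not match methyl in this assay.

No evidence is given that accounts for the gap between trifluoromethyl and fluoro. Going by these compounds, whether chloro, methoxy or an amine at this place would fall with trifluoromethyl or with fluoro and nitro remains open.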